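Pyrrolidine to Piperidine on a Thiocarbonyl Carbon: an Expected Step

This account rests on a few compounds, and the source may have more. Where it says the series, first, only, none or still open, it means among the compounds named here.

Of the compounds shown here, three have been measured in a functional assay on MCF7 cells (Homo sapiens) for antiproliferative activity, read by MTT assay, with a stated time of 72 h; on this read-out higher numbers stand for weaker inhibition and lower numbers for stronger inhibition. Compound 1 `Cc1ccc2c(=O)c(CSC(=S)N3CCCCC3)coc2c1` gives 800 nM in this assay. Compound 3 `Cc1ccc2c(=O)c(CSC(=S)N3CCCC3)coc2c1` gives 41400 nM in this assay. Compound 2 `O=c1c(SC(=S)N2CCCC2)coc2ccc(Cl)cc12` gives only a limit of the assay, > 25000 nM in this assay, and not a number. One step connects two of these: a 52-fold lower number from compound 3 to compound 1 (1.71 log units; beyond the scatter), the change being (piperidin-1-yl in place of pyrrolidin-1-yl on a thiocarbonyl carbon).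

Compound 4 `O=c1c(SC(=S)N2CCCCC2)coc2ccc(Cl)cc12` has not yet been measured. It differs from compound 2 by piperidin-1-yl in place of pyrrolidin-1-yl on a thiocarbonyl carbon, the same change as that from compound 3 to compound 1. The difference between the core of compound 2 and the core of compound 3 is not broken down here.

Because compound 2 sits at the limit of > 25000 nM in this assay, at which 1 of the 3 values shown sits, the size of the step from compound 2 to compound 4 cannot be fixed from the measurements alone, since the starting point is a limit rather than a number. If the change acts as it did from compound 3 to compound 1, compound 4 would be expected to fall inside the measurable range of this assay, though the starting point of compound 2 may lie anywhere at or past its limit.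

Compound 4 is therefore expected to give 3000 nM in this assay, with an expected range from 400 nM to 25000 nM. This expectation rests on a 52-fold lower number from compound 3 to compound 1 (1.71 log units; beyond the scatter) and amounts to an estimated step of an at least 8.3-fold lower number from compound 2 to compound 4 (0.92 log units; beyond the scatter).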

Compound 4, half-maximal inhibitory concentration: > 25000 nM
Compound 4: no number, only a limit; the forecaster's own chance of this, stated with the estimate: 25%; at least 8.3-fold (0.92 log units) between middle value and limit.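

In this assay, within the data shown here, compound 4, like compound 2, gives only a limit of the assay and not a number, so no step from compound 2 to compound 4 can be read, and both rest on one line: the limit of > 25000 nM in this assay, at which 2 of the 4 values shown sit. The compounds shown leave open whether piperidin-1-yl in place of pyrrolidin-1-yl on a thiocarbonyl carbon changes activity at all on the core shared by compound 2 and compound 4, and how far past the limit either compound lies.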